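Methyl on the Anilino Ring of a Quinazolinone Urea

The compounds below may be only part of what the source reports. "The series", "measured", "known", "first", "only" and "open" are said of these compounds alone.

Measured so far:
- compound 1, `O=C(Nc1ccccc1)Nn1c(-c2ccccc2)nc2ccccc2c1=O`: 56%
- compound 2, `CCc1nc2ccccc2c(=O)n1NC(=O)Nc1ccccc1`: 54%
- compound 3, `CCOc1ccc(NC(=O)Nn2c(-c3ccccc3)nc3ccccc3c2=O)cc1`: 53%

All three were tested in a functional assay on the whole organism (strain albino) with Mus musculus as the target, at a dose of 100 mg/kg by the intraperitoneal route; a lower number here means less inhibition, a higher number more inhibition at the dose given (going by the name of the read-out). Compound 2 sits second highest of the three numbers, but its nearest and furthest neighbours, compound 3 and compound 1, both lie within the scatter of it, so the three values cannot be told apart.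

Compound 4, `CCc1nc2ccccc2c(=O)n1NC(=O)Nc1ccccc1C`, differs from compound 2 in one place: methyl in place of hydrogen on an aromatic carbon. The change sits on the same ring that was altered in the step from compound 1 to compound 3, where a new group on that ring gave a number 3 percentage points lower from compound 1 to compound 3 (within the scatter). Among the measured compounds shown here, the only other step, a number 2 percentage points lower from compound 1 to compound 2 (within the scatter), also stayed within the scatter. Nothing measured points to a shift beyond the scatter, so the estimate for compound 4 is a number 1 percentage points lower from compound 2 to compound 4 (within the scatter), giving an expected value of 53% with a range from 40% to 66%.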

Compound 4, a percentage reported as inhibition, in the whole organism at one dose (the size of the read-out at that dose, not a potency): 54%
The estimate for compound 4 lay 1 percentage points below the measured number, within the range that was stated.
By their numbers in this assay, from the lowest: compounds 3, 2, 4 and 1 (each within the scatter of the next).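

In this assay the result is no change at the digits printed from compound 2 to compound 4 (within the scatter) when methyl replaces hydrogen on an aromatic carbon, ortho to a large group. Among the compounds shown here, this is the first reading of a change at this place on the anilino ring with ethyl on the core, and this single added carbon leaves the number where it was. Nothing measured here explains this outcome.

Still open, going by these compounds, is whether an amine, a carboxylic acid or a longer chain at this place would move the number beyond the scatter. Whether methyl behaves the same way on the core of compound 1 is also unknown.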